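From amide to urea: an untested analogue of compound 2

The source may hold more compounds than are shown below. What is called first, only, known or untested is meant among the compounds shown, and "the series" means these compounds.

Compound 2 `COc1cc(-c2nn(-c3cccc(NC(=O)c4cccc(C(F)(F)F)c4)c3)cc2-c2ccncc2)ccc1Cl` was measured in a functional assay on UACC-257 cells (Homo sapiens) for inhibition, read by sulforhodamine B assay, with a stated time of 48 h (on this read-out higher numbers stand for lower toxicity in this test and lower numbers for higher toxicity in this test), and gave > 50000 nM, which is a limit of the assay and not a number. Compound 1 `COc1cc(-c2nn(-c3cccc(NC(=O)Nc4cc(C(F)(F)F)cc(C(F)(F)F)c4)c3)cc2-c2ccncc2)ccc1Cl` gave 26200 nM in this assay. Compound 3 `O=C(Nc1cccc(-n2cc(-c3ccncc3)c(-c3ccc(Cl)c(O)c3)n2)c1)Nc1ccc(Cl)c(Cl)c1` gave > 32500 nM in this assay, again a limit rather than a number. So compound 2 stands at a limit, and one further value of the three shown is also a limit: one value sits at the limit of > 50000 nM in this assay, at which 1 of the 3 values shown sits, and one at the limit of > 32500 nM in this assay, at which 1 of the 3 values shown sits. Going by the values given here, no two measured compounds differ in only one place, so no single measured step is available for guidance.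

Compound 4 `COc1cc(-c2nn(-c3cccc(NC(=O)Nc4cccc(C(F)(F)F)c4)c3)cc2-c2ccncc2)ccc1Cl` has not yet been measured in this assay. It differs from compound 2 by (3-(trifluoromethyl)phenyl)amino in place of 3-(trifluoromethyl)phenyl on a carbonyl carbon, which gives compound 4 the same urea linkage carried by compound 1 and compound 3, on the shared core of compound 2. The step from compound 2 to compound 4 in this assay is expected to be small and toward higher toxicity, if any, as an at least 1.4-fold lower number from compound 2 to compound 4 (0.15 log units; that floor lies within the scatter), because compound 1 with a related urea gave 26200 nM. Compound 4 is therefore expected to give about 35000 nM in this assay, within 15000 nM to 60000 nM, with a fair chance that only a limit is reported.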

Compound 4, concentration lethal to 50% of the cells: 7580 nM
Estimate against measurement, compound 4: 4.6-fold (0.66 log units) above, outside the stated range (below it).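

In this assay, going by these compounds alone, (3-(trifluoromethyl)phenyl)amino in place of 3-(trifluoromethyl)phenyl on a carbonyl carbon gives an at least 6.5-fold lower number from compound 2 to compound 4 (0.81 log units; beyond the scatter), the first single change that can be read, and it shows that turning the amide linkage into a urea linkage on this core moves the read-out toward higher toxicity in this test. The value of compound 2 is a limit of the assay and not a number: the limit of > 50000 nM in this assay, at which 1 of the 4 values shown sits. On the urea linkage, the aromatic substitution also counts, since hydrogen in place of trifluoromethyl on an aromatic carbon gives a 3.5-fold lower number from compound 1 to compound 4 (0.54 log units; beyond the scatter), so the urea with a single trifluoromethyl stands at higher toxicity in this test than the one with two.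

Neither the limits shown nor anything else given here supplies a measured property that would account for these steps. Going by these compounds, the steps to compound 3 cannot be read, as it differs from the others in more than one place, and it remains open how this core would respond to a carbamate, a sulfonamide or a methylated urea as the linkage.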